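This account rests on a few compounds, and the source may have more. Where it says the series, first, only, none or still open, it means among the compounds named here.

Measured compounds:
compound 1 `Cc1c(OCCCCOCOc2ccc(C(=O)O)cc2)ccc(C(=O)CC2CCCC2)c1O` with 95.4%
compound 2 `CCC(=O)c1ccc(OCCCCOc2ccc(C(=O)O)cc2C)c(C)c1O` with 86.6%
compound 3 `Cc1c(OCCCCOc2ccc3ccc(=O)oc3c2)ccc(C(=O)CC(C)C)c1O` with 45.2%

In an assay on HEK293 cells for positive allosteric modulation of metabotropic glutamate receptor 2 (Rattus norvegicus), read by thallium flux, with a stated time of 2.5 min (a higher number here means a larger maximal response, a lower number a smaller maximal response), compound 1 gives the highest of the three numbers. Compound 2 comes nearest, a number lower than that of compound 1 but within the scatter, so the two cannot be ordered. Compound 3 sits furthest off, beyond the scatter below compound 1.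

Compound 4 `Cc1cc(OCCCCOc2ccc(C(=O)CC3CCCC3)c(O)c2C)ccc1C(=O)O` is not yet measured in this assay. It differs from compound 1 in one place: 4-carboxy-3-methylphenyl in place of (4-carboxyphenoxy)methyl on an oxygen on a saturated carbon. Among the compounds with values here, no step between measured compounds matches this change, so its size is unknown. Compound 2 also carries a carboxy group on a ring with a methyl, and compound 2 gives 86.6% in this assay. Compound 4 is therefore expected to stay close to compound 1, with a step of a number 5.4 percentage points lower from compound 1 to compound 4 (within the scatter) that is estimated to fall within the scatter. The estimate for compound 4 in this assay is 90%, ranging from 70% to 105%.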

Compound 4, largest response reached (reported as percent of maximum), in percent of the reference or control that the assay uses: 83.6%
Compound 4: the middle estimate sits 6.4 percentage points above what was measured; measured number inside the range.
By their numbers in this assay, from the lowest: compound 3; then compounds 4, 2 and 1 (each within the scatter of the next, the first and the last beyond it).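

Within the data shown here, on an oxygen on a saturated carbon, 4-carboxy-3-methylphenyl in place of (4-carboxyphenoxy)methyl gives the first readable step in this assay: a number 11.8 percentage points lower from compound 1 to compound 4 (beyond the scatter), modest but beyond the scatter. The change therefore costs some maximal response, yet compound 4 still gives 83.6%. Nothing at hand accounts for the step.

On these data alone, the step combines two changes, the added methyl and the shorter link, and their separate shares stay open. A 4-carboxyphenyl on that oxygen would separate them, and a tetrazole in place of the carboxylic acid remains a further open question.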